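Mirror-image change at the single stereocentre of compound 3

A few compounds are considered here, and "the series" means these few. Any claim that something is new, unique, unknown or untested is made for them only; others in the source may bear on it.

Three measured compounds share one core. In a functional assay on the whole organism (uterus) with Rattus norvegicus as the target, tested at 50 uM (a higher number here means a weaker effect of the compound at the concentration tested, a lower number a stronger effect), compound 1 `C[C@H](Nc1nc(O)c2cc(Cl)ccc2n1)C1CCCCC1` gives 66.5%. Compound 2 `Oc1nc(NCc2ccccc2)nc2ccc(Cl)cc12` gives 98.1%. Compound 3 `C[C@@H](Nc1nc(O)c2cc(Cl)ccc2n1)c1ccccc1` gives 46.5%, the lowest of the three numbers and so the strongest effect seen; the step of a number 51.6 percentage points lower from compound 2 to compound 3 (beyond the scatter) is the only measured step among these compounds. Compound 4 `C[C@H](Nc1nc(O)c2cc(Cl)ccc2n1)c1ccccc1` differs from compound 3 in this way: the two compounds have the same atoms and bonds and differ only in configuration as drawn: 1 of 1 stereo elements differ; a stereocentre at a saturated chain carbon is drawn R in compound 3 and S in compound 4. Within the data shown here, no measured pair differs by configuration alone, so no measured step bears on this change; the one known step concerns a methyl group, not a mirror-image form. The expectation for compound 4 is therefore wide: an estimated 72%, between 40% and 100%. This means an expected step of a number 25.5 percentage points higher from compound 3 to compound 4 (beyond the scatter), most likely toward a weaker effect.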

Compound 4, a percentage reported as activity, at one concentration (the size of the read-out at that concentration, not a potency): 44.9%
Estimate against measurement, compound 4: 27.1 percentage points above; low and high end bracket the measured number.
By their numbers in this assay, from the lowest: compounds 4 and 3 (each within the scatter of the next); then compound 1; then compound 2.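

In this assay, the mirror-image change at this carbon shows no difference beyond the scatter, with a number 1.6 percentage points lower from compound 3 to compound 4 (within the scatter), and the comparison isolates one feature: the fact that compounds 3 and 4 differ only in the configuration as drawn. The methyl group on this carbon therefore goes with a stronger effect in either drawn configuration, as the S form also gives a number 53.2 percentage points lower from compound 2 to compound 4 (beyond the scatter). With this configuration, the ring on the chain carbon also counts, with phenyl in place of cyclohexyl giving a number 21.6 percentage points lower from compound 1 to compound 4 (beyond the scatter).

From the compounds shown here alone, whether an ethyl group or a longer chain in place of the methyl would keep this effect remains open. So does the effect of a pyridine ring in place of the phenyl.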